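A few compounds are considered here, and "the series" means these few. Any claim that something is new, unique, unknown or untested is made for them only; others in the source may bear on it.

Working notes on the series. Three compounds have numbers in a functional assay on HT-29 cells (Homo sapiens) for cytotoxicity, read by MTT assay, with a stated time of 72 h; on this read-out higher numbers stand for weaker inhibition of growth and lower numbers for stronger inhibition of growth. Compound 1 `CSc1nc(NCCCc2ccccc2)c2ccccc2n1` gives 19600 nM, the lowest of the three. Compound 3 `CSc1ccc(CNc2nc(SC)nc3ccccc23)cc1` gives 34700 nM, which lies within the scatter of compound 1, so no order between those two can be claimed. Compound 2 `CSc1nc(NCCCCCO)c2cccnc2n1` gives 63900 nM, a number beyond the scatter from compound 1 and the weaker of that pair.

Compound 4 `CSc1nc(NCCCCCO)c2ccccc2n1` is not yet measured. Relative to compound 1 the change is 2-hydroxyethyl in place of phenyl on a saturated chain carbon, three bonds along the chain from a nitrogen on an aromatic ring. Among the compounds with values here, no step between measured compounds isolates this change, so its size is not known from the series. Within the data shown here, compound 4 shares its chain with compound 2, which sits at 63900 nM on a different core; that reading is the only related number and it points toward weaker growth inhibition. The change is expected to be a 1.8-fold higher number from compound 1 to compound 4 (0.25 log units; within the scatter), a modest move toward weaker growth inhibition, not clearly beyond the scatter. Compound 4 is therefore estimated at 35000 nM, with a range from 12000 nM to 100000 nM.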

Compound 4, concentration for 50% growth inhibition: > 100000 nM
Compound 4 ended at the assay's limit; the forecaster's own chance of this, stated with the estimate: 10%; middle value at least 2.8-fold (0.45 log units) from the limit.
By their numbers in this assay, from the lowest: compounds 1, 3 and 2 (each within the scatter of the next, the first and the last beyond it). At a limit, above all of these: compound 4.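

In this assay compound 4 stands at a limit of the assay and not at a number: the limit of > 100000 nM in this assay, at which 1 of the 4 values shown sits. The exchange of phenyl for 2-hydroxyethyl on a saturated chain carbon, three bonds along the chain from a nitrogen on an aromatic ring, gives an at least 5.1-fold higher number from compound 1 to compound 4 (0.70 log units; beyond the scatter), and the limit leaves the full size of this step unknown. Within the data shown here, this is the first step with a readable size, and it shows that growth inhibition on this core is sensitive to what sits at this place on the chain.

The compounds shown do not separate the loss of the phenyl ring from the entry of the hydroxyl group. A cyclohexyl group or an unsubstituted pentyl chain would tell these two apart, and an amine at the chain end would test whether other groups in place of phenyl give the same result.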